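The source may hold more compounds than are shown below. What is called first, only, known or untested is meant among the compounds shown, and "the series" means these compounds.

Compound 2, `COc1cc(OC)c(C(=O)c2ccccc2Br)c(O)c1CN1CCCCC1`, gives the lowest of the two numbers in a functional assay on THP-1 cells (Homo sapiens) for inhibition, read by ELISA, with stated times of 30 min and 24 h, tested at 1 uM (a higher number here means a stronger effect of the compound at the concentration tested, a lower number a weaker effect), at 22%; the nearest is compound 1, `COc1cc(OC)c(C(=O)c2cccc(Cl)c2)c(O)c1CN1CCCCC1`, with 33%. Among the compounds with values here, the single measured step bearing on the series is a number 11 percentage points lower from compound 1 to compound 2 (beyond the scatter). Compound 3, `COc1cc(OC)c(C(=O)c2cccc(F)c2)c(O)c1CN1CCCCC1`, differs from compound 2 by 3-fluorophenyl in place of 2-bromophenyl on a carbonyl carbon, which returns the halogen to the 3-position of the phenyl as in compound 1. Given that a number 11 percentage points lower from compound 1 to compound 2 (beyond the scatter) went down on moving to 2-bromophenyl, a rise of similar size back toward compound 1 is expected in this assay, so that a number 8 percentage points higher from compound 2 to compound 3 (within the scatter) is the estimated step. Compound 3 is estimated at 30%, within 15% to 45%.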

Compound 3, a percentage reported as activity, at one concentration (the size of the read-out at that concentration, not a potency): 30%
The estimate for compound 3 equals the measured number at the digits printed, within the range that was stated.
By their numbers in this assay, from the lowest: compounds 2, 3 and 1 (each within the scatter of the next, the first and the last beyond it).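

In this assay, 3-fluorophenyl in place of 2-bromophenyl on a carbonyl carbon gives a number 8 percentage points higher from compound 2 to compound 3 (within the scatter) and fluoro in place of chloro on an aromatic carbon gives a number 3 percentage points lower from compound 1 to compound 3 (within the scatter). Neither step separates its pair, so compound 3 does not sort with either compound 1 or compound 2. No measurement of any other property accompanies these steps.

On these data alone, whether an amine or a methoxy group on this phenyl would leave the read-out unchanged stays open. So does the effect of 2-fluorophenyl, which would separate halogen from placement.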